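From Chloro to (4-Chlorophenyl)amino on the Shared Core

The source may report more compounds than this note shows. Statements on the series, on what has been measured and on what is new or still open speak of the compounds shown alone.

Compound 1 `N#Cc1c(Cl)nc(SCC(=O)Nn2c(COc3ccc(Cl)cc3Cl)nc3ccccc3c2=O)nc1-c1ccccc1` was tested in a functional assay on the whole organism (strain albino) for inhibition, with Rattus norvegicus as the target, read by paw edema, with stated times of 1 h and 2 h, at a dose of 100 mg/kg by the oral route; on this read-out lower numbers stand for less inhibition and higher numbers for more inhibition at the one dose given (going by the name of the read-out). In this assay compound 1 gives 66.7%, the lowest of the two numbers seen. Its nearest neighbour is compound 2 `N#Cc1c(Cl)nc(SCC(=O)Nn2c(COc3ccc(Cl)cc3Cl)nc3ccccc3c2=O)nc1-c1ccc(O)cc1`; in this assay compound 2 gives 73.7%, and the step of a number 7 percentage points higher from compound 1 to compound 2 (within the scatter) lies within the scatter. Compound 3 `N#Cc1c(Nc2ccc(Cl)cc2)nc(SCC(=O)Nn2c(COc3ccc(Cl)cc3Cl)nc3ccccc3c2=O)nc1-c1ccccc1` differs from compound 1 by (4-chlorophenyl)amino in place of chloro on an aromatic carbon. Among the measured compounds shown here, no measured step touches that place; the only step known, hydroxy in place of hydrogen, stayed within the scatter and offers no direct guide. A change within the scatter is therefore expected, a number 1.7 percentage points lower from compound 1 to compound 3 (within the scatter). Compound 3 is estimated at 65%, between 50% and 80%.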

Compound 3, a percentage reported as inhibition, in the whole organism at one dose (the size of the read-out at that dose, not a potency): 57.9%
For compound 3 the middle estimate is 7.1 percentage points above the measured one, within the range that was stated.
By their numbers in this assay, from the lowest: compounds 3, 1 and 2 (each within the scatter of the next, the first and the last beyond it).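

Replacing the single chlorine atom with (4-chlorophenyl)amino, which brings eight heavy atoms, an extra aromatic ring and a hydrogen-bond donor, gives a number 8.8 percentage points lower from compound 1 to compound 3 (within the scatter) in this assay. This place on the shared core, ortho to the cyano group, can therefore carry a much larger group without a change beyond the scatter. No available data explain this result.

As far as these compounds go, how a small amine or a methoxy group would read at this place remains open. So does whether a morpholine ring would behave like (4-chlorophenyl)amino.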